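Branched alkyl in place of the methoxyphenyl arm

The source may hold more compounds than are shown below. What is called first, only, known or untested is meant among the compounds shown, and "the series" means these compounds.

Measured so far:
compound 1 `O=C(O)c1ccccc1-c1ccc(CCc2ncc(Cc3cccc(Cl)c3)[nH]2)cc1`, 825 nM
compound 2 `CC(C)(C)CCc1cnc(CCc2ccc(-c3ccccc3C(=O)O)cc2)[nH]1`, 39 nM
compound 3 `COc1ccc(Cc2cnc(CCc3ccc(-c4ccccc4C(=O)O)cc3)[nH]2)cc1`, 5360 nM

In an in vitro functional assay on cells for agonist activity at Bombesin receptor subtype-3 (Homo sapiens), read by luminescence and calcium flux (on this read-out lower numbers stand for an effect already at smaller amounts and higher numbers for an effect only at larger amounts of compound), compound 3 gives the highest number of the three. Its nearest neighbour is compound 1, and the gap is a 6.5-fold higher number from compound 1 to compound 3 (0.81 log units; beyond the scatter); the furthest is compound 2, with a 140-fold higher number from compound 2 to compound 3 (2.14 log units; beyond the scatter).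

Compound 4 `CCC(C)(CC)Cc1cnc(CCc2ccc(-c3ccccc3C(=O)O)cc2)[nH]1` is the next member. The change from compound 3 is 1-ethyl-1-methylpropyl in place of 4-methoxyphenyl on a saturated chain carbon bound to an aromatic carbon.

The step that bears most on this is the one already seen between the neopentyl and the methoxyphenyl arms, a 140-fold higher number from compound 2 to compound 3 (2.14 log units; beyond the scatter), run here in the opposite direction with a chain of the same kind, differing only in branching. The parallel step a 21-fold lower number from compound 1 to compound 2 (1.33 log units; beyond the scatter) also shows that a branched alkyl on this saturated chain carbon gives a markedly lower number than an arylmethyl group. A large step downward in this assay is therefore expected, roughly reversing the rise from compound 2 to compound 3, so that compound 4 is expected to land close to compound 2, with a 110-fold lower number from compound 3 to compound 4 (2.03 log units; beyond the scatter). The estimate for compound 4 is 50 nM, within 15 nM to 200 nM.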

Compound 4, half-maximal effective concentration: 76 nM
The estimate for compound 4 lay 1.5-fold (0.18 log units) below the measured number; the range from low to high includes it.
By their numbers in this assay, from the lowest: compounds 2 and 4 (each within the scatter of the next); then compound 1; then compound 3.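

In this assay, putting 1-ethyl-1-methylpropyl in place of neopentyl gives a 1.9-fold higher number from compound 2 to compound 4 (0.29 log units; within the scatter) and so shows no readable difference between these two branched alkyl arms. The step of a 71-fold lower number from compound 3 to compound 4 (1.85 log units; beyond the scatter) and the step of an 11-fold lower number from compound 1 to compound 4 (1.04 log units; beyond the scatter) both run the same way, so the lower number at this position is not unique to neopentyl and holds against both aryl arms shown. Nothing available here accounts for the gap between the alkyl and aryl arms.

Among these compounds, still open is whether branching itself matters, since an unbranched longer chain such as n-hexyl has no counterpart in this set. Also open, going by these compounds, is whether a saturated ring such as cyclohexyl, or an amine or hydroxyl on the alkyl arm, keeps the number as low as in the branched alkyl compounds.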